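A few compounds are considered here, and "the series" means these few. Any claim that something is new, unique, unknown or untested is made for them only; others in the source may bear on it.

Compound 1 `Cn1cc(C2=C(c3nn(CCCn4cccc4)c4ncccc34)C(=O)NC2=O)c2ccccc21`: > 100000 nM (a limit)
Compound 2 `Cn1cc(C2=C(c3nn(CCCn4ccnc4)c4ncccc34)C(=O)N(c3ccccc3)C2=O)c2ccccc21`: 1440 nM

Both compounds were tested in a functional assay on ECa-109 cells (Homo sapiens) for antiproliferative activity, read by MTT assay, with a stated time of 48 h; on this read-out higher numbers stand for weaker inhibition and lower numbers for stronger inhibition. Going by the values given here, compound 2, at 1440 nM, holds the only actual number in this small set. The result for compound 1, > 100000 nM, is a limit of the assay and not a number.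

Compound 3 `Cn1cc(C2=C(c3nn(CCCn4cccc4)c4ncccc34)C(=O)N(c3ccccc3)C2=O)c2ccccc21` has 1H-pyrrol-1-yl in place of 1H-imidazol-1-yl on a saturated chain carbon, three bonds along the chain from an aromatic nitrogen. Among the compounds with values here, no measured pair shows this change on its own, so any expectation is loosely anchored on compound 2 at 1440 nM. A modest loss of potency in this assay is expected, with the estimated step of a 2.8-fold higher number from compound 2 to compound 3 (0.44 log units; beyond the scatter) probably lying somewhat beyond the usual scatter. Compound 3 is estimated at 4000 nM, with an expected range of 1000 nM to 20000 nM.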

Compound 3, half-maximal inhibitory concentration: > 100000 nM
Compound 3: only a limit was reported; the forecaster's own chance of this, stated with the estimate: 12%; middle value at least 25-fold (1.39 log units) from the limit.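

In this assay, 1H-pyrrol-1-yl in place of 1H-imidazol-1-yl on a saturated chain carbon, three bonds along the chain from an aromatic nitrogen, gives an at least 69-fold higher number from compound 2 to compound 3 (1.84 log units; beyond the scatter). Going by these compounds alone, this is the first direct sign that this position tolerates little change here: swapping one five-membered aromatic ring for another, with the same number of heavy atoms, is enough to lose the measurable potency of compound 2. The full size of the step stays unknown, and compound 3 gives > 100000 nM, which is a limit of the assay and not a number: the limit of > 100000 nM in this assay, at which 2 of the 3 values shown sit.

Going by these compounds, the step from compound 1 to compound 3 cannot be read, so what phenyl on the amide-type nitrogen contributes remains open. On these data alone, it is also open whether an amine such as dimethylamino in place of 1H-imidazol-1-yl would keep the potency of compound 2.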